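The source may hold more compounds than are shown below. What is called first, only, known or untested is meant among the compounds shown, and "the series" means these compounds.

Measured so far:
compound 1 `Cc1cccc(NC(=O)N/N=C2\C(=O)Nc3ccccc32)c1` — > 25000 nM
compound 2 `O=C(N/N=C1\C(=O)Nc2ccccc21)Nc1ccccc1` — > 25000 nM
compound 3 `O=C1Nc2ccccc2/C1=N/NC(=S)Nc1ccccc1` — > 25000 nM

All three values come from an ADME assay on RD cells (Homo sapiens) for cytotoxicity; on this read-out lower numbers stand for higher toxicity in this test and higher numbers for lower toxicity in this test. Each of them is a limit of the assay rather than a number. For compound 2 the value > 25000 nM is such a limit. For compound 1 the value > 25000 nM is likewise a limit. For compound 3 the value > 25000 nM is a limit too, so the limit of > 25000 nM in this assay, at which 3 of the 3 values shown sit, gathers all three.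

Compound 1 and compound 2 differ by methyl in place of hydrogen on an aromatic carbon. Because both sit at the same limit, the step that the two limits leave unreadable from compound 2 to compound 1 cannot be read.

Compound 2 and compound 3 differ in their cores; how the two cores differ is not broken down here.

The compound still to be measured is compound 4 `Cc1ccc2c(c1)/C(=N/NC(=S)Nc1ccccc1)C(=O)N2`. Against compound 3 it shows (methyl in place of hydrogen on an aromatic carbon). This is the same kind of change as from compound 2 to compound 1, though not the same: there the place was on a six-membered aromatic ring of carbon only, meta to a large group, whereas here the ring is part of a fused or bridged system of two rings, meta to a fused ring and para to a fused ring.

Among the measured compounds shown here, since the one measured example of this change, a step that the two limits leave unreadable from compound 2 to compound 1, left both compounds at the limit, and compound 3 itself sits at > 25000 nM, compound 4 is expected to stay at the limit as well. The step that the limit leaves unreadable from compound 3 to compound 4 is therefore estimated to be small. For compound 4 in this assay the estimate is 40000 nM, with a range from 20000 nM to 100000 nM.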

Compound 4, half-maximal cytotoxic concentration: > 25000 nM
Compound 4 was reported as a limit; the forecaster's own chance of this, stated with the estimate: 85%; the middle value does not contradict the limit.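

Compound 4 is reported only as a limit, just as compound 3 is, so no new step can be read between compound 3 and compound 4. All the compounds shown now share one result: the limit of > 25000 nM in this assay, at which 4 of the 4 values shown sit. They leave open how toxic any of them is in this assay, and whether methyl in place of hydrogen on an aromatic carbon changes that read-out at all.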